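A Sulfonyl Chain on a Series Stuck at the Limit

A few compounds are considered here, and "the series" means these few. Any claim that something is new, unique, unknown or untested is made for them only; others in the source may bear on it.

In an ADME assay on cells (Peritoneal macrophage, Mus musculus) for cytotoxicity, read by CCK-8 assay, with a stated time of 24 h (a higher number here means that more compound is tolerated, a lower number that less compound is tolerated), three compounds sharing one core differ only in a single side chain. Compound 1 (`COc1ccc(S(=O)(=O)N(CC(N)=O)c2ccc(N(CC(N)=O)S(=O)(=O)c3ccc(SCCCN=C=S)cc3)c3ccccc23)cc1`) gives > 10000 nM, which is a limit and not a number. Compound 2 (`COc1ccc(S(=O)(=O)N(CC(N)=O)c2ccc(N(CC(N)=O)S(=O)(=O)c3ccc(SCCOCCN=C=S)cc3)c3ccccc23)cc1`) gives > 10000 nM, also a limit. On these data alone, compound 3 (`COc1ccc(S(=O)(=O)N(CC(N)=O)c2ccc(N(CC(N)=O)S(=O)(=O)c3ccc([S+]([O-])CCN=C=S)cc3)c3ccccc23)cc1`) gives > 10000 nM, again a limit, so its exact standing is unknown.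

Compound 4 (`COc1ccc(S(=O)(=O)N(CC(N)=O)c2ccc(N(CC(N)=O)S(=O)(=O)c3ccc(S(=O)(=O)CCN=C=S)cc3)c3ccccc23)cc1`) alters that chain of compound 3: a group of 8 heavy atoms (3 carbon, 1 nitrogen, 2 oxygen, 2 sulfur; no ring) in place of a group of 7 heavy atoms (3 carbon, 1 nitrogen, 1 oxygen, 2 sulfur; no ring), on an aromatic carbon. The change lies on an aromatic carbon, para to a large group.

Three measured steps changed this same chain: a step that the two limits leave unreadable from compound 1 to compound 2, a step that the two limits leave unreadable from compound 1 to compound 3 and a step that the two limits leave unreadable from compound 2 to compound 3. None has a readable size. Compound 3 and the other two all rest at the limit of > 10000 nM in this assay, at which 3 of the 3 values shown sit, so no step beyond the usual scatter is expected here. The estimated step is a step that the limit leaves unreadable from compound 3 to compound 4. For compound 4, the expected value is 12000 nM, with an estimated range of 6000 nM to 30000 nM, and another limit is the likeliest report.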

Compound 4, half-maximal cytotoxic concentration: > 10000 nM
Compound 4 was reported as a limit; the forecaster's own chance of this, stated with the estimate: 85%; the middle value lies beyond the limit too.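

Compound 4 gives > 10000 nM, which is a limit and not a number, so no step from compound 1, compound 2 or compound 3 to compound 4 can be read: the limit of > 10000 nM in this assay, at which 4 of the 4 values shown sit.

The compounds shown leave open whether these four side chains differ at all in this assay.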